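The source may hold more compounds than are shown below. What is called first, only, known or untested is meant among the compounds shown, and "the series" means these compounds.

Measured compounds in an assay on CHO cells for displacement of a labelled ligand from 5-hydroxytryptamine receptor 1D (Homo sapiens); a lower number here means a stronger inhibitor, a higher number a weaker inhibitor:
- compound 1 `O[C@H]1Cc2ccccc2C1NC1CCN(CCCc2c[nH]c3ccc(-n4cnnc4)cc23)CC1`: 37 nM
- compound 2 `c1ccc(CNCC2CCN(CCCc3c[nH]c4ccc(-n5cnnc5)cc34)CC2)cc1`: 1.6 nM
- compound 3 `O[C@@H]1Cc2ccccc2[C@H]1NC1CCN(CCCc2c[nH]c3ccc(-n4cnnc4)cc23)CC1`: 6.6 nM

Compound 1 gives the highest number of the three. Its nearest neighbour is compound 3, and the difference between them is a stereochemical one only: a 5.6-fold lower number from compound 1 to compound 3 (0.75 log units; beyond the scatter), which rests on (the fact that one of compounds 1 and 3 is drawn with a defined configuration and the other without, at the place where they differ). The larger movement is a 23-fold lower number from compound 1 to compound 2 (1.36 log units; beyond the scatter), where the (2-hydroxy-2,3-dihydro-1H-inden-1-yl)amino group gives way to (benzylamino)methyl. Between the two replacements on the saturated ring carbon, a 4.1-fold higher number from compound 2 to compound 3 (0.62 log units; beyond the scatter).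

Compound 4 `c1ccc(CNC2CCN(CCCc3c[nH]c4ccc(-n5cnnc5)cc34)CC2)cc1` is not yet measured. Relative to compound 1 the change is benzyl in place of 2-hydroxy-2,3-dihydro-1H-inden-1-yl on an amine nitrogen; the benzylamino group sits directly on the saturated ring carbon, one bond closer than in compound 2. The step from compound 1 to compound 2 is the one that bears on it, and it was large; the shorter linkage in compound 4 adds an unknown. For the measured compounds named here, a step to a lower number beyond the scatter is expected, a 7.4-fold lower number from compound 1 to compound 4 (0.87 log units; beyond the scatter), though smaller than the one to compound 2. Compound 4 is expected to give 5 nM in this assay, within 1.5 nM to 20 nM.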

Compound 4, half-maximal inhibitory concentration: 4.6 nM
Estimate against measurement, compound 4: 1.1-fold (0.04 log units) above; the range from low to high includes it.
By their numbers in this assay, from the lowest: compound 2; then compounds 4 and 3 (each within the scatter of the next); then compound 1.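

In this assay, benzyl in place of 2-hydroxy-2,3-dihydro-1H-inden-1-yl on the amine nitrogen reads differently with each partner: an 8.0-fold lower number from compound 1 to compound 4 (0.91 log units; beyond the scatter), but a 1.4-fold lower number from compound 3 to compound 4 (0.16 log units; within the scatter). With compound 3 as the partner, the fused five-membered ring and the hydroxyl give no step beyond the scatter, so the reading of this replacement depends on the stereochemistry of the group that leaves: the fact that one of compounds 1 and 3 is drawn with a defined configuration and the other without, at the place where they differ

The linkage also registers at this position, as benzylamino in place of (benzylamino)methyl on the saturated ring carbon gives a 2.9-fold higher number from compound 2 to compound 4 (0.46 log units; beyond the scatter).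

On these data alone, it remains open whether the hydroxyl matters on its own, which 2,3-dihydro-1H-inden-1-yl on the same amine nitrogen would test. Also open, as far as these compounds go, is how a longer chain such as 2-phenylethyl on that nitrogen would read.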